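The source may hold more compounds than are shown below. What is called first, only, known or untested is meant among the compounds shown, and "the series" means these compounds.

Of the compounds shown here, two have numbers so far. Compound 1 `CCCC1C(=O)N(C)c2cnc(Nc3ccc(S(N)(=O)=O)cc3)nc2N1C` carries a propyl group on a saturated ring carbon of the shared core; in an assay on Sf9 cells for inhibition of serine/threonine-protein kinase 4 (Homo sapiens), read by luminescence and ADP-Glo, with a stated time of 1 h, in the presence of a further agent that is not named here (on this read-out higher numbers stand for weaker inhibition and lower numbers for stronger inhibition), compound 1 gives 206 nM. Compound 2 `CN1C(=O)C(c2cccc(C(F)(F)F)c2)N(C)c2nc(Nc3ccc(S(N)(=O)=O)cc3)ncc21` carries a 3-(trifluoromethyl)phenyl on that saturated ring carbon instead, and in this assay compound 2 gives 2710 nM. Among the measured compounds shown here, the step of a 13-fold higher number from compound 1 to compound 2 (1.12 log units; beyond the scatter) is the only measured one, so compound 2 stands highest of the two numbers, with compound 1 as its only neighbour.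

Compound 3 `CCc1ccccc1C1C(=O)N(C)c2cnc(Nc3ccc(S(N)(=O)=O)cc3)nc2N1C` is not yet measured. Against compound 2 the change is 2-ethylphenyl in place of 3-(trifluoromethyl)phenyl on a saturated ring carbon. For the measured compounds named here, the one step that bears on it, a 13-fold higher number from compound 1 to compound 2 (1.12 log units; beyond the scatter), shows that in the single case examined an aromatic group on this carbon brought a markedly higher number than propyl. Going by the values given here, no measured pair sets one aromatic group against another on this carbon, so the outcome of swapping the trifluoromethyl-bearing ring for an ethyl-bearing ring is open. Compound 3 keeps an aromatic ring on this carbon and is expected to remain nearer compound 2 than compound 1. The expected step for compound 3 is a 1.4-fold lower number from compound 2 to compound 3 (0.13 log units; within the scatter), within or close to the scatter. The estimate for compound 3 in this assay is 2000 nM, with a range from 600 nM to 7000 nM.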

Compound 3, half-maximal inhibitory concentration: 51 nM
For compound 3 the middle estimate is 39-fold (1.59 log units) above the measured one; measured number below the stated range.
By their numbers in this assay, from the lowest: compound 3; then compound 1; then compound 2.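

Within this assay, an aromatic group on the saturated ring carbon no longer reads as unfavourable in itself: 2-ethylphenyl in place of propyl gives a 4.0-fold lower number from compound 1 to compound 3 (0.61 log units; beyond the scatter) and so runs opposite to the earlier 13-fold higher number from compound 1 to compound 2 (1.12 log units; beyond the scatter) for 3-(trifluoromethyl)phenyl in place of propyl. Among the compounds shown here, the identity of the aromatic group on this carbon therefore governs the outcome, since 2-ethylphenyl in place of 3-(trifluoromethyl)phenyl gives a 53-fold lower number from compound 2 to compound 3 (1.73 log units; beyond the scatter) and this is the largest step so far, although both groups carry one six-membered aromatic ring of carbon only. No supporting measurement accounts for these differences.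

The single exchange changes both the substituent and its numbered place on the aromatic ring, so the compounds shown cannot separate ethyl from trifluoromethyl or either of these from its place; 3-ethylphenyl and 2-(trifluoromethyl)phenyl on the same carbon would make that separation, with unsubstituted phenyl as the reference. Going by these compounds, it also remains open whether other groups here, such as 2-methylphenyl, 2-isopropylphenyl or a ring bearing an amine or a carboxylic acid, would follow compound 3 or compound 2.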